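Triazole thioacetohydrazones: aryl change at the hydrazone carbon

A few compounds are considered here, and "the series" means these few. Any claim that something is new, unique, unknown or untested is made for them only; others in the source may bear on it.

Measured so far:
compound 1 `O=C(CSc1nnc(-c2ccncc2)n1-c1ccccc1)N/N=C/c1ccc(Cl)cc1`, 9930 nM in a functional assay on MCF7 cells (Homo sapiens) for inhibition, read by MTT assay, with a stated time of 48 h; on this read-out lower numbers stand for stronger inhibition and higher numbers for weaker inhibition
compound 2 `O=C(CSc1nnc(-c2ccncc2)n1-c1ccccc1)N/N=C/c1ccccc1F`, 22400 nM in this assay

Among the measured compounds shown here, compound 2 holds the highest number of the two; the one step known, a 2.3-fold higher number from compound 1 to compound 2 (0.35 log units; beyond the scatter), is modest but beyond the scatter. Compound 3 `O=C(CSc1nnc(-c2ccncc2)n1-c1ccccc1)N/N=C/c1cc(Br)cc(Br)c1O` differs from compound 2 by 3,5-dibromo-2-hydroxyphenyl in place of 2-fluorophenyl on a carbon with a double bond to nitrogen. For the measured compounds named here, no measured step bears on this change directly; the only comparison in hand swaps one substituted phenyl for another and moved the number modestly. A similar or somewhat larger shift, more likely toward a lower number, is therefore expected, a 1.9-fold lower number from compound 2 to compound 3 (0.27 log units; within the scatter). Compound 3 is estimated at 12000 nM, within 3000 nM to 50000 nM.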

Compound 3, half-maximal inhibitory concentration: 8440 nM
Beside the measured number, compound 3's estimate is 1.4-fold (0.15 log units) above it; the measured number falls inside the stated range.
By their numbers in this assay, from the lowest: compounds 3 and 1 (each within the scatter of the next); then compound 2.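

Placing 3,5-dibromo-2-hydroxyphenyl on the carbon with a double bond to nitrogen gives a 2.7-fold lower number from compound 2 to compound 3 (0.42 log units; beyond the scatter), so the position accepts a larger, more heavily substituted aryl group without a rise in the number. Set against 4-chlorophenyl, the same change gives a 1.2-fold lower number from compound 1 to compound 3 (0.07 log units; within the scatter), so two differently substituted aryl groups read alike in this assay. Nothing at hand explains this likeness or the separation of compound 2.

Going by these compounds, the hydroxyl and the two bromines enter together, so their separate contributions remain open. On these data alone, how an aryl group bearing an amine or a carboxylic acid would read here also remains open.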